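Amino in place of chloro on a weak antiproliferative core

The source may report more compounds than this note shows. Statements on the series, on what has been measured and on what is new or still open speak of the compounds shown alone.

Compound 2 `Nc1nn(C(=O)Nc2ccc(Cc3ccccc3)cc2)c2ccc(Cl)cc12` is examined in a functional assay on PC-3 cells (Homo sapiens) for antiproliferative activity, read by sulforhodamine B assay, with a stated time of 48 h (a higher number here means a weaker inhibitor of growth, a lower number a stronger inhibitor of growth), where compound 2 gives 44300 nM. Within the data shown here, its only measured neighbour, compound 1 `Nc1nn(C(=O)Nc2ccc(Cc3ccccc3)cc2)c2ccccc12`, gives 51100 nM in this assay, and the two values lie within the scatter of each other, so neither compound can be called the more active. Among the measured compounds shown here, the one measured step, a 1.2-fold lower number from compound 1 to compound 2 (0.06 log units; within the scatter), is the only guide to the site now varied, and it shows that substitution there left this assay essentially unchanged. Compound 3 `Nc1ccc2c(c1)c(N)nn2C(=O)Nc1ccc(Cc2ccccc2)cc1` differs from compound 2 by amino in place of chloro on an aromatic carbon. For the measured compounds named here, no measured step involves an amino group at this place, so the expectation rests on the small size of the chloro step alone. Compound 3 is therefore expected to give 45000 nM in this assay, within a range of 18000 nM to 110000 nM. This estimate means a step of a 1.0-fold higher number from compound 2 to compound 3 (0.01 log units; within the scatter), which is expected to stay within the scatter.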

Compound 3, concentration for total growth inhibition: 24000 nM
Compound 3: the middle estimate sits 1.9-fold (0.27 log units) above what was measured; low and high end bracket the measured number.
By their numbers in this assay, from the lowest: compounds 3, 2 and 1 (each within the scatter of the next, the first and the last beyond it).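

Among these compounds, measured in this assay the amino group gives the first step at this position that goes beyond the scatter, with a 2.1-fold lower number from compound 1 to compound 3 (0.33 log units; beyond the scatter) set against the chloro step, which stayed within it. The direct exchange, a 1.8-fold lower number from compound 2 to compound 3 (0.27 log units; within the scatter) in a step that stays within the scatter, does not separate amino from chloro, so the two groups cannot be ranked at this place and only amino stands apart from hydrogen, by a modest margin. No evidence is at hand that bears on why the amino group behaves in this way.

As far as these compounds go, whether a hydroxyl, a methoxy or an acetamido group at this position would move the number further remains open. Also open, from the compounds shown here alone, is whether the amino step would hold with a change elsewhere on the shared core.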